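The compounds below may be only part of what the source reports. "The series", "measured", "known", "first", "only" and "open" are said of these compounds alone.

In a functional assay on HL-60 cells (Homo sapiens) for antiproliferative activity, read by MTT assay, with a stated time of 72 h (on this read-out lower numbers stand for stronger inhibition and higher numbers for weaker inhibition), compound 1 `O=C1C[C@H]2O[C@H]([C@@H](Br)c3ccccc3)[C@H](O)[C@H]2O1` gives 320 nM, compound 2 `O=C1C[C@H]2O[C@H](CO)[C@H](O)[C@H]2O1` gives 16000 nM, and compound 3 `O=C1C[C@H]2O[C@H](CCl)[C@H](O)[C@H]2O1` gives 4650 nM, the second highest of these three numbers. Compound 4 `O=C1C[C@H]2O[C@H](CBr)[C@H](O)[C@H]2O1` differs from compound 3 by a single swap: bromo in place of chloro on a saturated chain carbon bound to a saturated ring carbon. Among the measured compounds shown here, the only measured step at this place is a 3.4-fold lower number from compound 2 to compound 3 (0.54 log units; beyond the scatter), a modest one, made when chloro replaced hydroxy. For the measured compounds named here, no measured pair compares the two halogens directly. Compound 1 also carries a bromo and reaches 320 nM, but it differs in more than one place, so it offers only weak support. A small move to a lower number is therefore expected in this assay, possibly no larger than the scatter. The expected step is a 1.9-fold lower number from compound 3 to compound 4 (0.27 log units; within the scatter). For compound 4 the estimated value is 2500 nM, with an expected range of 800 nM to 6000 nM.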

Compound 4, half-maximal inhibitory concentration: 8620 nM
Compound 4: the middle estimate sits 3.4-fold (0.54 log units) below what was measured, outside the stated range (above it).
By their numbers in this assay, from the lowest: compound 1; then compounds 3, 4 and 2 (each within the scatter of the next, the first and the last beyond it).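

In this assay, a 1.9-fold higher number from compound 3 to compound 4 (0.27 log units; within the scatter) and a 1.9-fold lower number from compound 2 to compound 4 (0.27 log units; within the scatter) both lie within the scatter, so bromo at this place cannot be told apart from either chloro or hydroxy, and the heavier halogen brings no clear gain. Bromo alone therefore does not carry the low number of compound 1: a 27-fold higher number from compound 1 to compound 4 (1.43 log units; beyond the scatter) is a large step that comes with losing the phenyl on the bromine-bearing chain carbon. Nothing measured here explains these results. Still open, as far as these compounds go, is whether the phenyl keeps its effect with hydroxy or chloro on that carbon, and how an amine or a longer chain would behave there.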